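Removing the Butyl Chain from Compound 3

The source may hold more compounds than are shown below. What is called first, only, known or untested is meant among the compounds shown, and "the series" means these compounds.

In a functional assay on MCF7 cells (Homo sapiens) for inhibition, read by fluorescence, with a stated time of 72 h (on this read-out lower numbers stand for stronger inhibition of growth and higher numbers for weaker inhibition of growth), compound 3 `CCCCc1cc2nn(-c3ccccc3)cc2cn1` gives 13300 nM. Compound 1 `CCCCCc1cc2nn(-c3ccccc3)cc2cn1` gives 11800 nM, and a 1.1-fold higher number from compound 1 to compound 3 (0.05 log units; within the scatter), so these two compounds sit together within the scatter. Compound 2 `OCCc1cc2nn(-c3ccccc3)cc2cn1` reaches only the limit of the assay, > 100000 nM. Compound 4 `c1ccc(-n2cc3cnccc3n2)cc1` is not yet measured; the change is hydrogen in place of butyl on an aromatic carbon. Within the data shown here, two measured steps bear on this chain: an at least 8.4-fold higher number from compound 1 to compound 2 (0.92 log units; beyond the scatter) and an at least 7.5-fold lower number from compound 2 to compound 3 (0.87 log units; beyond the scatter), both of which altered the chain rather than removing it, while a 1.1-fold higher number from compound 1 to compound 3 (0.05 log units; within the scatter) shows that adding one carbon to the alkyl chain changes little. Taking the whole chain away is expected to weaken growth inhibition, giving a 4.5-fold higher number from compound 3 to compound 4 (0.65 log units; beyond the scatter). Compound 4 is therefore estimated at 60000 nM, with a range from 15000 nM to 200000 nM.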

Compound 4, concentration for 50% growth inhibition: > 100000 nM
Compound 4: only a limit was reported; the forecaster's own chance of this, stated with the estimate: 40%; middle value at least 1.6-fold (0.22 log units) away from the limit.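

Taking the chain off this aromatic carbon costs growth inhibition in this assay, with an at least 7.5-fold higher number from compound 3 to compound 4 (0.87 log units; beyond the scatter) and an at least 8.4-fold higher number from compound 1 to compound 4 (0.92 log units; beyond the scatter). The value of compound 4 is a limit of the assay, so both steps give only a minimum size. Among these compounds, measurable inhibition appears only with butyl or pentyl on this carbon, and compound 2, with 2-hydroxyethyl, sits at the same limit as compound 4, so the step between them cannot be read: the limit of > 100000 nM in this assay, at which 2 of the 4 values shown sit.

From the compounds shown here alone, whether a shorter chain such as methyl or ethyl keeps any inhibition remains open. So does how a longer chain or an amine on this carbon would behave.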